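The source may hold more compounds than are shown below. What is called first, only, known or untested is meant among the compounds shown, and "the series" means these compounds.

Compound 1, `CNC(=O)c1cc(C(=O)NC2CC2)cn([C@H](C)c2ccccc2)c1=O`: >= 168 ug/mL
Compound 2, `CNC(=O)c1cc(C(=O)NC(C)C)cn(Cc2ccccc2)c1=O`: >= 136 ug/mL
Compound 3, `CNC(=O)c1cc(C(=O)NC2CC2)cn(Cc2ccccc2F)c1=O`: >= 145 ug/mL

All three share one core and differ only in the group on the aromatic nitrogen and in the group on the amide-type nitrogen. In a physicochemical assay for solubility (a lower number here means a less soluble compound, a higher number a more soluble compound), compound 2 gives >= 136 ug/mL, and this is a limit of the measurement, not a number. The two further values shown are limits as well, so compound 2 cannot be placed above or below either of them; it sits at the limit of >= 136 ug/mL in this assay, at which 1 of the 3 values shown sits, while the others sit at the limit of >= 145 ug/mL in this assay, at which 1 of the 3 values shown sits, and (the limit of >= 168 ug/mL in this assay, at which 1 of the 3 values shown sits).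

Compound 4, `CNC(=O)c1cc(C(=O)NC2CCC2)cn(Cc2ccccc2)c1=O`, has not yet been measured. It differs from compound 2 in one place: cyclobutyl in place of isopropyl on an amide-type nitrogen. The only step measured between two of these compounds is a step that the two limits leave unreadable from compound 1 to compound 3, which concerns the aromatic nitrogen and not the amide-type nitrogen, so no measured step bears directly on the change to compound 4.

With every value shown resting at a limit, the step from compound 2 to compound 4 is expected to be small or none beyond the scatter, as an at least 1.1-fold lower number from compound 2 to compound 4 (0.05 log units; that floor lies within the scatter). Compound 4 is therefore estimated at 120 ug/mL, with a range from 50 ug/mL to 200 ug/mL.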

Compound 4, solubility: 28 ug/mL
Compound 4: middle estimate off by 4.3-fold (0.63 log units), on the high side; the whole stated range lies above it.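

In this assay, the amide-type nitrogen proves to be a place where the read-out can move: putting cyclobutyl in place of isopropyl gives an at least 4.8-fold lower number from compound 2 to compound 4 (0.68 log units; beyond the scatter). Until now every value shown was a limit. Compound 4 gives 28 ug/mL, a plain number, and it shows that a small swap of one carbon-only group for another on this nitrogen need not leave the result unchanged. The size of this step is only a floor, because compound 2 carries a limit rather than a number: the limit of >= 136 ug/mL in this assay, at which 1 of the 4 values shown sits.

Going by these compounds, the step between compound 1 and compound 3 cannot be read, since both values are limits, so what the group on the aromatic nitrogen does in this assay remains open. The data do not tell whether the lower number goes with the four-membered ring or with the larger carbon group as such. An open chain such as n-butyl on the same amide-type nitrogen could help to answer this question.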